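Side-chain link and halogen swap in the series

A few compounds are considered here, and "the series" means these few. Any claim that something is new, unique, unknown or untested is made for them only; others in the source may bear on it.

compound 1 `C=C1CC[C@@H]2[C@](C)(CO)[C@H](O)CC[C@@]2(C)[C@@H]1CCC1C(=O)OC[C@H]1O`: > 30000 nM
compound 2 `C=C1CC[C@@H]2[C@](C)(CNCc3ccc(F)cc3)[C@H](O)CC[C@@]2(C)[C@@H]1/C=C/C1=CCOC1=O`: 350 nM
compound 3 `C=C1CC[C@@H]2[C@](C)(CNCc3ccc([N+](=O)[O-])cc3)[C@H](O)CC[C@@]2(C)[C@@H]1/C=C/C1=CCOC1=O`: 1340 nM

In a functional assay on BMMC cells (Mus musculus, strain C57BL/6) for inhibition, with stated times of 5 days and 48 h (a higher number here means a weaker inhibitor, a lower number a stronger inhibitor), compound 2 gives 350 nM, the lowest of the two numbers measured. Compound 3 gives 1340 nM. For compound 1 this assay reports only a limit, > 30000 nM. That single entry is the one at the limit of > 30000 nM in this assay, at which 1 of the 3 values shown sits.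

Going by the values given here, the only measured step is a 3.8-fold higher number from compound 2 to compound 3 (0.58 log units; beyond the scatter), a change of the aromatic substituent alone. Compound 4 `C=C1CC[C@H]2[C@@](C)(CC[C@@H](O)[C@@]2(C)C(=O)NCc2ccc(Br)cc2)[C@@H]1/C=C/C1=CCOC1=O` differs from compound 2 by (4-bromobenzyl)carbamoyl in place of ((4-fluorobenzyl)amino)methyl on a saturated ring carbon. Among the compounds with values here, the halogen exchange on the ring is a smaller change than the fluoro-to-nitro step, but no measured step covers the exchange of the aminomethyl link for a carbamoyl one, so the bearing of the measured data on compound 4 is weak. A step of modest size toward a higher number, in line with the move from compound 2 to compound 3 but with wide uncertainty, is expected.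

Compound 4 is therefore estimated at 1500 nM, between 400 nM and 6000 nM. The step this estimate implies is expected to be a 4.3-fold higher number from compound 2 to compound 4 (0.63 log units; beyond the scatter).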

Compound 4, half-maximal inhibitory concentration: 3450 nM
Compound 4: middle estimate off by 2.3-fold (0.36 log units), on the low side; the measured number falls inside the stated range.
By their numbers in this assay, from the lowest: compound 2; then compound 3; then compound 4. At a limit, above all of these: compound 1.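

In this assay the exchange of ((4-fluorobenzyl)amino)methyl for (4-bromobenzyl)carbamoyl on the saturated ring carbon gives a 9.9-fold higher number from compound 2 to compound 4 (0.99 log units; beyond the scatter) and is the first step shown that alters the link at this position, not only the aromatic substituent. Compound 4 still gives a measured number, so inhibition in this series survives the carbamoyl link, though with a loss beyond the scatter. The link and the halogen change together in this one step, and nothing shown gives a cause for the loss.

Going by these compounds, the separate shares of link and halogen remain open, and the (4-fluorobenzyl)carbamoyl or ((4-bromobenzyl)amino)methyl partner would divide them. Also open, on these data alone, is how a phenethyl group in place of benzyl, or a carboxylic acid on the aromatic ring, would read at this position.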